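This account rests on a few compounds, and the source may have more. Where it says the series, first, only, none or still open, it means among the compounds named here.

Compound 2, `O=C(Nc1cnc(NCc2c(F)ccc3c2CCO3)n2cnnc12)c1ccccc1`, gives 3 in a physicochemical assay for lipophilicity, using the shake flask method, in phosphate buffer, measured as octanol-water partition, with a stated time of 30 min, at pH 7.4; on this read-out lower numbers stand for lower lipophilicity and higher numbers for higher lipophilicity. Compound 1, `CN(C(=O)c1ccccc1)c1cnc(NCc2c(F)ccc3c2CCO3)n2cnnc12`, carries methyl in place of hydrogen on an amide-type nitrogen and gives 2.4, so the step of a number 0.60 log units lower from compound 2 to compound 1 (beyond the scatter) is modest but beyond the scatter. Compound 3, `CNC(=O)c1ccc(-c2cnc(NCc3c(F)ccc4c3CCO4)c3cn[nH]c(=O)c23)c(C)n1`, gives 2.9; the difference between its core and that of compound 2 is not broken down here. Compound 4, `Cc1nc(C(=O)N(C)C)ccc1-c1cnc(NCc2c(F)ccc3c2CCO3)c2cn[nH]c(=O)c12`, differs from compound 3 by methyl in place of hydrogen on an amide-type nitrogen. This is the same kind of change as that from compound 2 to compound 1, not the same: there the nitrogen's other neighbours are an aromatic carbon and a carbonyl carbon, here a carbonyl carbon and a saturated chain carbon. Resting on the earlier step of a number 0.60 log units lower from compound 2 to compound 1 (beyond the scatter), the step for compound 4 is expected to be a number 0.20 log units lower from compound 3 to compound 4 (within the scatter), smaller than that earlier step. Compound 4 is therefore estimated at 2.7, between 2.3 and 3.2.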

Compound 4, distribution coefficient: 2.1
Compound 4: middle estimate off by 0.60 log units, on the high side, and the stated range ends above it.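

In this assay, methyl in place of hydrogen on an amide-type nitrogen goes with a lower number in both pairs: a number 0.80 log units lower from compound 3 to compound 4 (beyond the scatter) and a number 0.60 log units lower from compound 2 to compound 1 (beyond the scatter). The direction therefore carries from one core to the other, even though the nitrogen's other neighbours differ, but two pairs make no rule for the series and do not show whether the core or those neighbours set the size of the step. No measurement shown here explains the result.

The compounds shown leave open how an ethyl group or a longer chain on the same nitrogen would read on either core. They also leave open how a carboxylic acid in place of the dimethylcarbamoyl would read.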